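A few compounds are considered here, and "the series" means these few. Any claim that something is new, unique, unknown or untested is made for them only; others in the source may bear on it.

Compound 3 `Cc1ncnc2c1c(-c1cccs1)cn2[C@@H]1O[C@H](CO)[C@@H](O)[C@H]1O` carries a methyl group and a thiophen-2-yl group on its shared core. In a functional assay on CEM-DNR-bulk cells (Homo sapiens), read by MTT assay, with a stated time of 72 h (a higher number here means a weaker inhibitor, a lower number a stronger inhibitor), compound 3 gives only a limit of the assay, > 20000 nM, not a number. The same limit marks compound 1 `CN(C)c1ncnc2c1c(-c1ccsc1)cn2[C@@H]1O[C@H](CO)[C@@H](O)[C@H]1O`, whose value in this assay is > 20000 nM. Compound 2 `C#Cc1cn([C@@H]2O[C@H](CO)[C@@H](O)[C@H]2O)c2ncnc(N(C)C)c12` differs from compound 1 by an ethynyl group in place of a thiophen-3-yl group; in this assay compound 2 reaches 240 nM. That change gives an at least 83-fold lower number from compound 1 to compound 2 (1.92 log units; beyond the scatter). Compound 4 `CN(C)c1ncnc2c1c(-c1cccs1)cn2[C@@H]1O[C@H](CO)[C@@H](O)[C@H]1O` differs from compound 3 in one place: dimethylamino in place of methyl on an aromatic carbon. Among the compounds with values here, no measured step changes this position, so the only guide is that (the limit of > 20000 nM in this assay, at which 2 of the 3 values shown sit), and compound 1, which shares the dimethylamino group and a thiophene ring with compound 4, sits there. Compound 4 is therefore expected to stay at or near that limit, an estimated step of a number no higher from compound 3 to compound 4 (the limit leaves the size open). The expected value for compound 4 is 20000 nM, within a range from 5000 nM to 60000 nM.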

Compound 4, half-maximal inhibitory concentration: > 20000 nM
Compound 4 gave a limit, no number; the forecaster's own chance of this, stated with the estimate: 75%; the middle value sits exactly at the limit.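

Putting thiophen-2-yl in place of ethynyl on an aromatic carbon gives an at least 83-fold higher number from compound 2 to compound 4 (1.92 log units; beyond the scatter) in this assay, so with dimethylamino held fixed, the ethynyl result is lost with this thiophene as it was with thiophen-3-yl. The steps joining compound 4 to compound 3 and to compound 1 cannot be read, as each has a limit at both ends, so neither the exchange of methyl for dimethylamino nor the choice between the two thiophenes can be sized here. Compound 4 gives only a limit of the assay, not a number, and it is the same limit seen before: the limit of > 20000 nM in this assay, at which 3 of the 4 values shown sit.

On these data alone, whether methyl and dimethylamino differ when ethynyl rather than a thiophene sits on the shared core remains open. So does the effect of other groups at the ethynyl place, such as a nitrile or a longer alkyne chain.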